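Notes on one stereocentre inversion, compound 1 to compound 4

The source may hold more compounds than are shown below. What is called first, only, known or untested is meant among the compounds shown, and "the series" means these compounds.

Measured in a functional assay on HCC827 cells (Homo sapiens) for antiproliferative activity, read by MTT assay, with a stated time of 72 h; a higher number here means a weaker inhibitor, a lower number a stronger inhibitor:
compound 1 `CN1CCN(c2ccc(Nc3ncc4nc(Nc5ccc(F)cc5)n([C@H]5CCCC(NC(=O)OC(C)(C)C)C5)c4n3)cc2)CC1`: 120 nM
compound 2 `CN1CCN(c2ccc(Nc3ncc4nc(Nc5ccccc5)n([C@H]5CCN(S(=O)(=O)C6CC6)C5)c4n3)cc2)CC1`: 1.6 nM
compound 3 `CN1CCN(c2ccc(Nc3ncc4nc(Nc5ccc(F)cc5)n([C@H]5CCN(S(=O)(=O)C6CC6)C5)c4n3)cc2)CC1`: 7.5 nM

Compound 1 gives the highest of the three numbers in this assay; compound 3 lies nearest to it and compound 2 furthest, both gaps beyond the scatter.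

Compound 4 `CN1CCN(c2ccc(Nc3ncc4nc(Nc5ccc(F)cc5)n([C@@H]5CCCC(NC(=O)OC(C)(C)C)C5)c4n3)cc2)CC1` differs from compound 1 in configuration only: the two compounds have the same atoms and bonds; at least one stereo element is drawn with a configuration in one of them and without one in the other: 1 of 2 stereo elements differ; a stereocentre at a saturated ring carbon is drawn S in compound 1 and R in compound 4. For the measured compounds named here, the single measured step, a 4.7-fold higher number from compound 2 to compound 3 (0.67 log units; beyond the scatter), concerns fluoro in place of hydrogen on an aromatic carbon and says nothing about configuration at a saturated ring carbon. Going by the values given here, no measured step bears on the present change, so neither its direction nor its size is indicated; inversion of one stereocentre could move the number either way. The step in this assay is therefore expected to be no change at the digits printed from compound 1 to compound 4 (within the scatter), with a wide range. Compound 4 is estimated at 120 nM, between 30 nM and 500 nM.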

Compound 4, half-maximal inhibitory concentration: 280 nM
The estimate for compound 4 lay 2.3-fold (0.37 log units) below the measured number; measured number inside the range.
By their numbers in this assay, from the lowest: compound 2; then compound 3; then compound 1; then compound 4.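

Inversion at this saturated ring carbon, with atoms and bonds unchanged, gives a 2.3-fold higher number from compound 1 to compound 4 (0.37 log units; beyond the scatter) in this assay. Configuration at this position therefore registers in the read-out, with the S drawing giving the lower number. This reading carries one caution: the fact that one of compounds 1 and 4 is drawn with a defined configuration and the other without, at the place where they differ.

Still open, as far as these compounds go, is whether the inversion keeps its direction and size when a free amine or an acetamide replaces the tert-butyl carbamate on that ring. From the compounds shown here alone, the contribution of the second stereo element also remains open.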